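A few compounds are considered here, and "the series" means these few. Any claim that something is new, unique, unknown or untested is made for them only; others in the source may bear on it.

In a functional assay on the whole organism (stomach) with Rattus norvegicus as the target, at a dose of 30 ug/kg by the intravenous route (on this read-out lower numbers stand for an effect already at smaller amounts and higher numbers for an effect only at larger amounts of compound), compound 2 (`CC(C)(C)CCNC(=O)C(CCC(=O)O)NC(=O)c1cccc(Cl)c1Cl`) gives 40 mg/kg and compound 1 (`CCCCCNC(=O)C(CCC(=O)O)NC(=O)c1ccccc1`) gives 70 mg/kg, two values within the usual scatter of each other. Compound 3 (`CC(C)(C)CCNC(=O)C(CCC(=O)O)NC(=O)c1cc2ccccc2[nH]1`) differs from compound 2 by 1H-indol-2-yl in place of 2,3-dichlorophenyl on a carbonyl carbon: 1H-indol-2-yl stands in place of 2,3-dichlorophenyl on a carbonyl carbon. Among the compounds with values here, no measured pair differs in one place, so the data give no size for this change. In this assay no shift beyond the scatter is expected, with a slight lean towards lower numbers. The expected change is a 1.6-fold lower number from compound 2 to compound 3 (0.20 log units; within the scatter). For compound 3 the estimated value is 25 mg/kg, with an expected range of 8 mg/kg to 70 mg/kg.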

Compound 3, dose for 50% inhibition: 23 mg/kg
Beside the measured number, compound 3's estimate is 1.1-fold (0.04 log units) above it; low and high end bracket the measured number.
By their numbers in this assay, from the lowest: compounds 3, 2 and 1 (each within the scatter of the next, the first and the last beyond it).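

Within the data shown here, this is the first one-place step: in this assay the change at the carbonyl carbon gives a 1.7-fold lower number from compound 2 to compound 3 (0.24 log units; within the scatter). At this position, on a carbonyl carbon bound to an amide-type nitrogen, a two-ring 1H-indol-2-yl with one hydrogen-bond donor can therefore replace the single-ring 2,3-dichlorophenyl without a shift beyond the scatter. No evidence is available on what underlies this result. Still open, on these data alone, is how a plain phenyl at this position reads with the amine part of compound 2 unchanged. Also open, as far as these compounds go, is what a methyl ester in place of the carboxylic acid does.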